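From 4-hydroxycyclohexyl to 4-methoxycyclohexyl in compound 3

The compounds below may be only part of what the source reports. "The series", "measured", "known", "first", "only" and "open" are said of these compounds alone.

Measured so far in an in vitro ADME assay on microsomes (Mus musculus) for metabolic stability; a higher number here means that the compound lasts longer, a lower number that the compound disappears faster:
- Compound 1 `CCNC(=O)Nc1ccc(-c2nc(N3CC4CCC(C3)O4)c3cnn(C4CCC5(CC4)OCCO5)c3n2)cc1` gives 0.45 h as a number
- Compound 2 `CNC(=O)Nc1ccc(-c2nc(N3CC4CCC(C3)O4)c3cnn([C@H]4CC[C@@H](O)CC4)c3n2)cc1` gives > 0.5 h as a limit

Compound 2 stands at a limit in this assay, > 0.5 h, and not at a true number. Compound 3 `CNC(=O)Nc1ccc(-c2nc(N3CC4CCC(C3)O4)c3cnn([C@H]4CC[C@H](OC)CC4)c3n2)cc1` keeps the rest of compound 2 but carries 4-methoxycyclohexyl in place of 4-hydroxycyclohexyl on an aromatic nitrogen. This swap removes the hydrogen-bond donor of the 4-hydroxycyclohexyl group. For the measured compounds named here, compound 1 and compound 2 differ in more than one place, so no measured step shows what a change like this does. Going by the values given here, the only firm number is that of compound 1 at 0.45 h, so the expectation stays close to that level. No large move is expected in either direction, and the expected change is an at least 1.2-fold lower number from compound 2 to compound 3 (0.09 log units; that floor lies within the scatter), which would be nothing beyond the usual scatter. For compound 3 the estimated half-life is 0.4 h, with an expected range from 0.2 h to 0.8 h.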

Compound 3, half-life: > 0.5 h
Compound 3: no number, only a limit (the forecaster's own chance of this, stated with the estimate: 40%); at least 1.2-fold (0.09 log units) between middle value and limit.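

For the compounds shown here, no step from compound 2 to compound 3 can be read in this assay, because neither compound has a true number, only a limit: the limit of > 0.5 h in this assay, at which 2 of the 3 values shown sit.

The compounds shown leave open whether 4-methoxycyclohexyl in place of 4-hydroxycyclohexyl on an aromatic nitrogen makes a compound last longer, makes it disappear faster, or leaves its half-life unchanged.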